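The source may report more compounds than this note shows. Statements on the series, on what has been measured and on what is new or still open speak of the compounds shown alone.

Compound 2 `Cc1ccnc(Oc2ccc(CC3SC(=O)NC3=O)cc2)c1` gives the highest of the three numbers measured in a functional assay for agonist activity at Free fatty acid receptor 1 (Homo sapiens), read by FLIPR, in the presence of a further agent that is not named here (on this read-out lower numbers stand for an effect already at smaller amounts and higher numbers for an effect only at larger amounts of compound), at 4280 nM. Compound 1 `Cc1cc(Oc2ccc(CC3SC(=O)NC3=O)cc2)nc(C(F)(F)F)c1` gives 688 nM in this assay, and compound 3 `Cc1cc(C(F)(F)F)cc(Oc2ccc(CC3SC(=O)NC3=O)cc2)n1` gives 218 nM. Among the measured compounds shown here, the one step measured between close pairs is that from compound 1 to compound 2, a 6.2-fold higher number from compound 1 to compound 2 (0.79 log units; beyond the scatter), which concerns the trifluoromethyl group and not the position of the methyl group. Compound 4 `Cc1cccnc1Oc1ccc(CC2SC(=O)NC2=O)cc1` is not yet measured; it differs from compound 2 by 3-methylpyridin-2-yl in place of 4-methylpyridin-2-yl on an oxygen on an aromatic ring. For the measured compounds named here, no measured step bears directly on moving the methyl group on this ring; compounds 1 and 3 differ from each other in two places at once, so their values alone cannot be read as a single step. Compound 1 gives 688 nM. Compound 3 gives 218 nM. Going by the values given here, with no step in hand that speaks to the change, compound 4 is expected to stay within the scatter of compound 2, giving an estimated step of a 1.0-fold higher number from compound 2 to compound 4 (0.00 log units; within the scatter). The value for compound 4 in this assay is therefore estimated at 4300 nM, with a range from 1400 nM to 13000 nM.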

Compound 4, half-maximal effective concentration: 1090 nM
Estimate against measurement, compound 4: 3.9-fold (0.60 log units) above, outside the stated range (below it).
By their numbers in this assay, from the lowest: compound 3; then compounds 1 and 4 (each within the scatter of the next); then compound 2.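

In this assay, putting 3-methylpyridin-2-yl in place of 4-methylpyridin-2-yl on the oxygen gives a 3.9-fold lower number from compound 2 to compound 4 (0.59 log units; beyond the scatter) and so shows that the place of the methyl group on this ring matters on its own. The earlier step concerned the loss of a trifluoromethyl group, whereas here the two compounds have the same atoms, joined differently, and the number still moves beyond the scatter. No measurement at hand accounts for this shift.

From the compounds shown here alone, it remains open whether the gain from the 3-methylpyridin-2-yl arrangement would carry over to a ring that also bears a trifluoromethyl group. Going by these compounds, it is equally open how an ethyl group, a methoxy group or an amine would fare in place of the methyl group on this ring.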